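Carbamoylmethyl at the Ring Nitrogen: Expected Response

The compounds below may be only part of what the source reports. "The series", "measured", "known", "first", "only" and "open" are said of these compounds alone.

Measured compounds:
- Compound 1 `COc1ccc(Cn2c(=O)n(C3OC(CO)[C@@H](O)[C@H]3O)c3nc(N)nc(O)c32)cc1` gives 14% in a functional assay on the whole organism with Mus musculus as the target; on this read-out lower numbers stand for smaller maximal responses and higher numbers for larger maximal responses.
- Compound 2 `CCCCCCn1c(=O)n(C2OC(CO)[C@@H](O)[C@H]2O)c2nc(N)nc(O)c21` gives 11% in this assay.
- Compound 3 `Cn1c(=O)n(C2OC(CO)[C@@H](O)[C@H]2O)c2nc(N)nc(O)c21` gives 100% in this assay.

Compound 3 stands highest of the three numbers, with compound 1 nearest and compound 2 furthest, both separated from it beyond the scatter. The two measured steps that end at compound 3 both replace a larger group on the saturated chain carbon bound to the aromatic nitrogen with hydrogen: a number 86 percentage points higher from compound 1 to compound 3 (beyond the scatter) and a number 89 percentage points higher from compound 2 to compound 3 (beyond the scatter). The step of a number 3 percentage points lower from compound 1 to compound 2 (within the scatter) shows that the two larger groups give numbers within the scatter of each other.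

Compound 4 `NC(=O)Cn1c(=O)n(C2OC(CO)[C@@H](O)[C@H]2O)c2nc(N)nc(O)c21` carries carbamoyl in place of hydrogen on a saturated chain carbon bound to an aromatic nitrogen. Both relevant steps show that enlarging the group at this place lowers the response strongly, so a drop is expected in this assay, estimated to be a number 60 percentage points lower from compound 3 to compound 4 (beyond the scatter). For compound 4 the expected value is 40%, with a range from 10% to 85%.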

Compound 4, largest response reached (reported as maximal response), in percent of the reference or control that the assay uses: 72%
Estimate against measurement, compound 4: 32 percentage points below; low and high end bracket the measured number.
By their numbers in this assay, from the lowest: compounds 2 and 1 (each within the scatter of the next); then compound 4; then compound 3.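

Growing methyl into carbamoylmethyl still costs response in this assay (a number 28 percentage points lower from compound 3 to compound 4 (beyond the scatter)), so at this saturated chain carbon bound to an aromatic nitrogen, each larger group shown gives a lower number than hydrogen. The loss, however, is not the same for every group: carbamoyl keeps far more of the response than pentyl (a number 61 percentage points higher from compound 2 to compound 4 (beyond the scatter)) and 4-methoxyphenyl (a number 58 percentage points higher from compound 1 to compound 4 (beyond the scatter)), which shows that the identity of the group matters, not merely whether one is present. No supporting data explain why carbamoyl fares better.

From the compounds shown here alone, whether a carboxylic acid, an amine or a hydroxyl in place of carbamoyl would keep as much response remains open. So does whether a longer chain ending in carbamoyl would behave like carbamoylmethyl.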